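Methyl on the chain: working notes toward compound 4

The compounds below may be only part of what the source reports. "The series", "measured", "known", "first", "only" and "open" are said of these compounds alone.

Compound 1 `O=C(CCCCCNc1c(Nc2ccccc2)c(=O)c1=O)NO` gives 47000000 nM in a physicochemical assay for solubility, read by HPLC, in phosphate buffer, with a stated time of 24 h, at pH 7.4, tested at 100 uM; a higher number here means a more soluble compound, a lower number a less soluble compound. Compound 2 `O=C(CCCCCNc1c(NCc2ccccc2)c(=O)c1=O)NO` gives 75000000 nM in this assay, and compound 3 `C[C@@H](Nc1c(NCCCCCC(=O)NO)c(=O)c1=O)c1ccccc1` gives 80000000 nM in this assay. Compound 4 `CC(CCCCC(=O)NO)Nc1c(Nc2ccccc2)c(=O)c1=O` has not yet been measured.

The change from compound 2 to compound 3 is methyl in place of hydrogen on a saturated chain carbon bound to an aromatic carbon and a nitrogen on an aromatic ring; it made a 1.1-fold higher number from compound 2 to compound 3 (0.03 log units; within the scatter). The cores of compound 1 and compound 2 differ as phenyl in place of benzyl on a nitrogen on an aromatic ring. The change from compound 1 to compound 4 is methyl in place of hydrogen on a saturated chain carbon bound to a nitrogen on an aromatic ring and a saturated chain carbon. Going by the values given here, this is the same kind of change as the one from compound 2 to compound 3, not the same: in compound 3 the carbon carrying the methyl is bound to an aromatic carbon and a nitrogen on an aromatic ring, whereas in compound 4 it is bound to a nitrogen on an aromatic ring and a saturated chain carbon.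

The step from compound 1 to compound 4 in this assay is expected to be a 1.1-fold higher number from compound 1 to compound 4 (0.04 log units; within the scatter), set beside the earlier 1.1-fold higher number from compound 2 to compound 3 (0.03 log units; within the scatter), which rests on that matching step having stayed within the scatter. Compound 4 is accordingly estimated at 52000000 nM, between 25000000 nM and 105000000 nM.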

Compound 4, solubility: 93000000 nM
Estimate against measurement, compound 4: 1.8-fold (0.25 log units) below; the measured number falls inside the stated range.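

In this assay, methyl in place of hydrogen gives a 2.0-fold higher number from compound 1 to compound 4 (0.30 log units; within the scatter), while the matching change on the core of compound 2 gives a 1.1-fold higher number from compound 2 to compound 3 (0.03 log units; within the scatter), so on both cores the step stays within the scatter. Going by these compounds alone, this shows that no step beyond the scatter appears with this change in either of these two pairs, but it does not show that a single methyl effect carries from one core to another, since there is only one pair per core and the methyl does not stand on the same kind of carbon: in compound 4 it is on a saturated chain carbon bound to a nitrogen on an aromatic ring and a saturated chain carbon. No measured evidence bears on why the numbers fall as they do.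

The compounds shown leave open whether ethyl, an amine or a carboxylic acid in place of that methyl would give a step beyond the scatter. They also leave open whether a longer chain would alter the size of the methyl step.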